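Series notes: ester on the piperidine ring, compound 3

The source may hold more compounds than are shown below. What is called first, only, known or untested is meant among the compounds shown, and "the series" means these compounds.

Measured in an assay on isolated protein (Cavia porcellus) with Sigma non-opioid intracellular receptor 1 (Homo sapiens) as the target, read by radioligand binding; on this read-out lower numbers stand for stronger inhibition and higher numbers for weaker inhibition:
compound 1 `CN(C)CCCCCCCCCOc1ccc2oc(-c3ccccc3)cc(=O)c2c1`: 202 nM
compound 2 `O=c1cc(-c2ccccc2)oc2ccc(OCCCCCCN3CCCCC3)cc12`: 54 nM

Compound 2 holds the lower of the two numbers in this assay, with compound 1 the nearest, set apart by a 3.7-fold lower number from compound 1 to compound 2 (0.57 log units; beyond the scatter). Compound 3 `CCOC(=O)C1CCN(CCCCCCOc2ccc3oc(-c4ccccc4)cc(=O)c3c2)CC1` is not yet measured. It differs from compound 2 by ethoxycarbonyl in place of hydrogen on a saturated ring carbon. For the measured compounds named here, no measured step touches a ring carbon of this kind: the only step seen, a 3.7-fold lower number from compound 1 to compound 2 (0.57 log units; beyond the scatter), exchanged the amine end of the chain as a whole and therefore bears on compound 3 only loosely. With nothing closer to lean on, the expectation for compound 3 is a step that stays near the scatter, without a firm direction, written as a 1.3-fold higher number from compound 2 to compound 3 (0.11 log units; within the scatter). Compound 3 is accordingly estimated at 70 nM, with a range from 25 nM to 200 nM.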

Compound 3, half-maximal inhibitory concentration: 102 nM
Estimate against measurement, compound 3: 1.5-fold (0.16 log units) below; the range from low to high includes it.
By their numbers in this assay, from the lowest: compounds 2, 3 and 1 (each within the scatter of the next, the first and the last beyond it).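

In this assay the step of a 1.9-fold higher number from compound 2 to compound 3 (0.28 log units; within the scatter) shows that the saturated ring carbon three ring bonds from the ring nitrogen takes ethoxycarbonyl, with its 5 heavy atoms, without a difference that stands clear of the scatter. With 4-(ethoxycarbonyl)piperidin-1-yl as the amine end, the step of a 2.0-fold lower number from compound 1 to compound 3 (0.30 log units; within the scatter) also lies within the scatter, whereas the plain piperidin-1-yl end gave a 3.7-fold lower number from compound 1 to compound 2 (0.57 log units; beyond the scatter) and stood beyond it. Nothing available here explains these numbers.

On these data alone, whether the ester itself matters at this ring carbon remains open, since a carboxylic acid, a primary amide or a hydroxymethyl group there could be read against ethoxycarbonyl. Also open, as far as these compounds go, is whether the same tolerance holds with a shorter or longer chain between the oxygen and the piperidine nitrogen.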